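Swapping one ring group on compound 2

A few compounds are considered here, and "the series" means these few. Any claim that something is new, unique, unknown or untested is made for them only; others in the source may bear on it.

Values in an ADME assay on PBMC cells (Homo sapiens) for cytotoxicity, with a stated time of 72 h (a lower number here means a stronger inhibitor, a higher number a weaker inhibitor), are these:
Compound 1 `O=C(NO)c1cc(F)c(Cn2nnc(-c3ccco3)n2)c(F)c1` stands at > 1000 nM as a limit
Compound 2 `Cn1c(Sc2c(F)cc(C(=O)NO)cc2F)nnc1-c1cccnn1` stands at > 1000 nM as a limit
Compound 3 `O=C(NO)c1ccc(Cn2nnc(-c3ncccn3)n2)cc1` stands at > 1000 nM as a limit

Compound 2 has no exact number, and its place is shared with the other two compounds, as the limit of > 1000 nM in this assay, at which 3 of the 3 values shown sit, makes plain. No order among the three can be told from these readings.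

Compound 4 `Cc1cc(-c2nnc(Sc3c(F)cc(C(=O)NO)cc3F)n2C)nn1C` keeps the core of compound 2 but carries 1,5-dimethyl-1H-pyrazol-3-yl in place of pyridazin-3-yl on an aromatic carbon. Among the measured compounds shown here, the counted difference is 1,5-dimethyl-1H-pyrazol-3-yl in place of pyridazin-3-yl on an aromatic carbon and it is the only change.

For the measured compounds named here, no measured pair shows what a single change does in this assay here. The expectation rests on compound 2 with its limit of > 1000 nM as the starting point. No step beyond the scatter is expected, and another limit is the likeliest report. The expected move is a step that the limit leaves unreadable from compound 2 to compound 4 and it should stay small. Compound 4 is estimated at 1500 nM with an expected range from 700 nM to 5000 nM as its span.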

Compound 4, half-maximal inhibitory concentration: > 1000 nM
Compound 4: a limit, no number; the forecaster's own chance of this, stated with the estimate: 80%; the middle value does not contradict the limit.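

No step can be read between compound 2 and compound 4 in this assay, since both readings are limits and not numbers: the limit of > 1000 nM in this assay, at which 4 of the 4 values shown sit.

The compounds shown leave open whether 1,5-dimethyl-1H-pyrazol-3-yl in place of pyridazin-3-yl changes the true inhibitory concentration at all.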